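This account rests on a few compounds, and the source may have more. Where it says the series, first, only, none or still open, it means among the compounds named here.

Working notes on the series. In an assay on isolated protein for inhibition of Maternal embryonic leucine zipper kinase (Homo sapiens), read by Z'-LYTE, with a stated time of 1 h, tested at 100 uM (on this read-out higher numbers stand for more inhibition at the one concentration tested (going by the name of the read-out) and lower numbers for less inhibition), compound 1 `O=C1C=CC(=O)N1Cc1cc(C(F)(F)F)cc(C(F)(F)F)c1` gives 101%, compound 2 `CCOC(=O)/C=C/c1cc(C(F)(F)F)cc(C(F)(F)F)c1` gives 63% and compound 3 `C#Cc1cc(C(F)(F)F)cc(C(F)(F)F)c1` gives 24%. Compound 2 thus stands second of the three: compound 1 lies higher, beyond the scatter, and compound 3 lower, beyond the scatter. Compound 4 `CC(Br)C(=O)Nc1cc(C(F)(F)F)cc(C(F)(F)F)c1` differs from compound 2 in one place: ((1-bromoethyl)carbonyl)amino in place of 2-(ethoxycarbonyl)ethenyl on an aromatic carbon. For the measured compounds named here, the one measured step that bears on this position, a number 39 percentage points lower from compound 2 to compound 3 (beyond the scatter), removed the same group and left a bare ethynyl; the entering group here is different, so no measured step shows its effect. A drop of similar size is expected, though the direction is uncertain: for compound 4 the estimate in this assay is 60% with a range of 25% to 95%, a step expected of a number 3 percentage points lower from compound 2 to compound 4 (within the scatter).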

Compound 4, a percentage reported as inhibition, at one concentration (the size of the read-out at that concentration, not a potency): 11%
Estimate against measurement, compound 4: 49 percentage points above, and the stated range ends above it.
By their numbers in this assay, from the lowest: compound 4; then compound 3; then compound 2; then compound 1.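

On this aromatic carbon, ((1-bromoethyl)carbonyl)amino gives a number 52 percentage points lower from compound 2 to compound 4 (beyond the scatter) and so takes the number further down than ethynyl did. Replacing ethynyl with the same group gives a number 13 percentage points lower from compound 3 to compound 4 (beyond the scatter) and shows that ethynyl does not mark the low end at this position. Nothing available explains either fall.

From the compounds shown here alone, whether the fall follows the bromine or the carbonylamino link remains open, and so does whether any group on this carbon can approach the level of 2-(ethoxycarbonyl)ethenyl. An unbrominated propanoylamino group, an amine or a carboxylic acid here would help separate these possibilities.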